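The compounds below may be only part of what the source reports. "The series", "measured", "known", "first", "only" and "open" are said of these compounds alone.

In a functional assay on B16-F10 cells (Mus musculus) for antiproliferative activity, read by MTT assay, with a stated time of 48 h (a lower number here means a stronger inhibitor, a higher number a weaker inhibitor), compound 1 `CC(=O)N1N=C(c2ccc3ccccc3c2)OC1c1ccc(Br)cc1` gives 4.68 ug/mL and compound 2 `CC(=O)N1N=C(c2ccc3ccccc3c2)OC1c1ccc([N+](=O)[O-])cc1` gives 9.32 ug/mL under the same conditions. Nitro in place of bromo on an aromatic carbon amounts to a 2.0-fold higher number from compound 1 to compound 2 (0.30 log units; within the scatter) and so compound 2 stands within the scatter of compound 1, the only other measured compound in the series.

The change from compound 2 to compound 3 `CC(=O)N1N=C(c2ccc3ccccc3c2)OC1c1cccnc1` is pyridin-3-yl in place of 4-nitrophenyl on a saturated ring carbon and reads as pyridin-3-yl in place of 4-nitrophenyl on a saturated ring carbon, next to the ring oxygen. Among the measured compounds shown here, the only measured step that bears on it is a 2.0-fold higher number from compound 1 to compound 2 (0.30 log units; within the scatter) and that step exchanged a group on the aromatic ring, leaving the ring itself in place. For the measured compounds named here, no measured compound has a hetero atom in that aromatic ring, so the guide is a loose one.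

With this single step inside the scatter, no step beyond the scatter is expected in this assay in either direction. The expected step is a 1.0-fold lower number from compound 2 to compound 3 (0.02 log units; within the scatter) on this reading. For compound 3 the estimate is 9 ug/mL as the expected value, with 3.5 ug/mL to 25 ug/mL as its expected range.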

Compound 3, half-maximal inhibitory concentration: 3.06 ug/mL
Estimate against measurement, compound 3: 2.9-fold (0.47 log units) above; measured number outside the range, below it.
By their numbers in this assay, from the lowest: compounds 3, 1 and 2 (each within the scatter of the next, the first and the last beyond it).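

In this assay, among the compounds shown here, pyridin-3-yl in place of 4-nitrophenyl on the saturated ring carbon gives a 3.0-fold lower number from compound 2 to compound 3 (0.48 log units; beyond the scatter), the first step to pass beyond the scatter. This change replaces the whole aromatic ring with one holding a hetero atom, whereas the earlier step only exchanged a group on a ring of carbon only. Against the bromo compound, the same replacement gives a 1.5-fold lower number from compound 1 to compound 3 (0.18 log units; within the scatter), so at this position the pyridin-3-yl compound separates from compound 2 but not from compound 1, and no measurement at hand accounts for that separation.

As far as these compounds go, it stays open whether pyridin-2-yl or pyridin-4-yl would read with compound 3 or with compound 2, and whether a phenyl ring carrying an amine or a carboxylic acid would fall on either side of that separation. Also open, from the compounds shown here alone, is how far the reading at this ring carbon would hold with a longer chain such as propanoyl in place of the acetyl group on the ring nitrogen.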